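A few compounds are considered here, and "the series" means these few. Any claim that something is new, unique, unknown or untested is made for them only; others in the source may bear on it.

In an assay on HEK293 cells for positive allosteric modulation of metabotropic glutamate receptor 3 (Rattus norvegicus), read by thallium flux, with a stated time of 2.5 min (on this read-out higher numbers stand for larger maximal responses and lower numbers for smaller maximal responses), two compounds have been measured so far. Compound 1, `COC(=O)c1ccc(OCCCCOc2ccc(C(=O)CC3CCCC3)c(O)c2C)cc1`, gives 22%. Compound 2, `CC(=O)c1ccc(OCCCCOc2ccc(F)c(C(=O)O)c2)c(C)c1O`, gives 16.8%; this number and that of compound 1 lie within the usual scatter of each other, so neither compound stands apart. Compound 3, `Cc1c(OCCCCOc2ccc(F)c(C(=O)O)c2)ccc(C(=O)CC2CCCC2)c1O`, has not yet been measured. It differs from compound 2 by cyclopentyl in place of hydrogen on a saturated chain carbon bound to a carbonyl carbon. For the measured compounds named here, no measured pair shows this change alone, so the expected step from compound 2 to compound 3 is a number 3.2 percentage points higher from compound 2 to compound 3 (within the scatter), not beyond the scatter. The estimate for compound 3 in this assay is 20%, expected to fall between 8% and 35%.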

Compound 3, largest response reached (reported as percent of maximum), in percent of the reference or control that the assay uses: 98.4%
Compound 3: the middle estimate sits 78.4 percentage points below what was measured, and the stated range ends below it.
By their numbers in this assay, from the lowest: compounds 2 and 1 (each within the scatter of the next); then compound 3.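

In this assay, cyclopentyl in place of hydrogen on a saturated chain carbon bound to a carbonyl carbon gives a number 81.6 percentage points higher from compound 2 to compound 3 (beyond the scatter), so the group at this position strongly affects the maximal response. Replacing 4-(methoxycarbonyl)phenyl with 3-carboxy-4-fluorophenyl gives a number 76.4 percentage points higher from compound 1 to compound 3 (beyond the scatter), so among these three compounds, only the one carrying both cyclopentyl and 3-carboxy-4-fluorophenyl reaches a high response. No measured evidence here explains either step. The compounds shown leave open whether a cyclohexyl or cyclopropyl ring would serve as well as cyclopentyl, and whether an amide could replace the carboxylic acid.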